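This account rests on a few compounds, and the source may have more. Where it says the series, first, only, none or still open, it means among the compounds named here.

Working notes on the series in a functional assay on the whole organism (artery, strain albino) with Rattus norvegicus as the target, with a stated time of 720 min, at a dose of 10 mg/kg by the oral route; on this read-out higher numbers stand for more inhibition at the one dose given (going by the name of the read-out) and lower numbers for less inhibition.

Compound 1 `COc1ccc(C2N=C(SCc3ccc(Cl)cc3)NC(C)=C2C(=O)Nc2ccc(F)cc2)cc1OC` carries a (4-chlorobenzyl)sulfanyl group; in this assay compound 1 gives 22.2%. Compound 2 `COc1ccc(C2N=C(SCc3ccc(F)cc3)NC(C)=C2C(=O)Nc2ccc(F)cc2)cc1OC` differs from compound 1 by one change, (fluoro in place of chloro on an aromatic carbon), and in this assay compound 2 gives 17%. The step of a number 5.2 percentage points lower from compound 1 to compound 2 (within the scatter) stays within the usual scatter of repeated measurements, so these two values are not told apart.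

Compound 3 `CC1=C(C(=O)Nc2ccc([N+](=O)[O-])cc2)C(c2ccc(Br)cc2)N=C(SCc2ccc(Cl)cc2)N1` has a different core; the difference between the core of compound 3 and the core of compound 1 is not broken down here. In this assay compound 3 gives 29.4%. The two values of compound 3 and compound 1 are within the scatter of each other; the value of compound 3 and the value of compound 2 lie beyond it.

Compound 4 `CC1=C(C(=O)Nc2ccc([N+](=O)[O-])cc2)C(c2ccc(Br)cc2)N=C(SCc2ccc(F)cc2)N1` is not yet measured. It differs from compound 3 by fluoro in place of chloro on an aromatic carbon, the same change that turns compound 1 into compound 2, and the place of the change is the same in both pairs. Among the compounds with values here, the only measured instance of this change is the step of a number 5.2 percentage points lower from compound 1 to compound 2 (within the scatter), which was within the scatter. On the core of compound 3 a step of similar size is expected, a number 5.4 percentage points lower from compound 3 to compound 4 (within the scatter), resting on that single pair and on the value of compound 3, 29.4%. Within the data shown here, since only one earlier instance exists, the range is kept wide. Compound 4 is thus estimated at 24%, between 12% and 36%.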

Compound 4, a percentage reported as inhibition, in the whole organism at one dose (the size of the read-out at that dose, not a potency): 27.3%
Compound 4: middle estimate off by 3.3 percentage points, on the low side; the range from low to high includes it.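

In this assay, the swap of chloro for fluoro on the benzyl ring, read on the core of compound 3, gives a number 2.1 percentage points lower from compound 3 to compound 4 (within the scatter), and it can be set beside the earlier instance of the same change: the same change on two cores in this assay, a number 5.2 percentage points lower (within the scatter) from compound 1 to compound 2 and a number 2.1 percentage points lower (within the scatter) from compound 3 to compound 4, 3.1 percentage points apart, within the scatter of two such steps

On these two cores, then, the change behaves alike: in neither pair can the two values be told apart, and the two steps cannot be told apart from each other. This does not show that the change is without effect in general or that the agreement would hold on a third core, since it rests on two pairs, each with a step inside the scatter, and two steps of this kind leave little room to detect any dependence on the core. Nor does it say which part of the difference between the two cores matters for the read-out, as the cores differ in more than one place.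

The compounds shown carry only chloro or fluoro at this place on the benzyl ring, so it remains open whether an amine, a carboxylic acid or a methyl group there would shift the value beyond the scatter. Also open, on these data alone, is what a longer chain in place of the benzyl group would do on either core.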